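Removing a methyl group from compound 2

The source may hold more compounds than are shown below. What is called first, only, known or untested is meant among the compounds shown, and "the series" means these compounds.

Measured in a functional assay on A2780 cells (Homo sapiens) for inhibition, read by sulforhodamine B assay; a lower number here means a stronger inhibitor of growth, a higher number a weaker inhibitor of growth:
Compound 1 `COc1ccc(-c2ccc(-c3ccc(-c4nc5cc(C)ccc5[nH]4)cc3)cc2)cc1OC`: 2130 nM
Compound 2 `COc1cc(-c2ccc(-c3ccc(-c4nc5cc(C)ccc5[nH]4)cc3)cc2)cc(OC)c1OC`: 190 nM

Compound 2 has the lower of the two numbers, which makes it the stronger growth inhibitor. Compound 3 `COc1cc(-c2ccc(-c3ccc(-c4nc5ccccc5[nH]4)cc3)cc2)cc(OC)c1OC` has hydrogen in place of methyl on an aromatic carbon. Within the data shown here, the only measured step, an 11-fold lower number from compound 1 to compound 2 (1.05 log units; beyond the scatter), was large, but it put methoxy in place of hydrogen and left the methyl untouched, so it says little here. Among the measured compounds shown here, with no measured step on this methyl, no change beyond the scatter is expected, and the estimated step is a 1.3-fold higher number from compound 2 to compound 3 (0.10 log units; within the scatter). Compound 3 is expected at 240 nM, with an estimated range of 80 nM to 700 nM.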

Compound 3, concentration for 50% growth inhibition: 9210 nM
Beside the measured number, compound 3's estimate is 38-fold (1.58 log units) below it, and the stated range ends below it.
By their numbers in this assay, from the lowest: compound 2; then compound 1; then compound 3.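

In this assay the change is a 48-fold higher number from compound 2 to compound 3 (1.69 log units; beyond the scatter) on losing a single carbon, so this methyl on the six-membered aromatic ring, part of the fused system, matters greatly for growth inhibition. The earlier step concerned only a methoxy at the other end, and this one shows that the 5-methyl-1H-benzimidazol-2-yl end is also sensitive. Nothing available explains the loss. Going by these compounds, whether ethyl, chlorine or an amine on the same carbon could stand in for methyl remains open, as does whether removing this methyl from compound 1 would cost as much.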